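Trimethoxyphenyl on the carbonyl side of the chalcone-pyrazole series

The source may report more compounds than this note shows. Statements on the series, on what has been measured and on what is new or still open speak of the compounds shown alone.

Compound 1 `COc1ccc(C(=O)/C=C/c2cc(-c3cc(OC)c(OC)c(OC)c3)n[nH]2)cc1OC` is the strongest of the three measured compounds in a functional assay on UACC-257 cells (Homo sapiens) for cytotoxicity, read by sulforhodamine B assay, with a stated time of 48 h, tested at 100 uM; a lower number here means a stronger effect, a higher number a weaker effect of the compound at the concentration tested: compound 1 gives -97%, while compound 3 `COc1cc(-c2cc(/C=C/C(=O)c3ccc(F)c(F)c3)[nH]n2)cc(OC)c1OC` gives -37% and compound 2 `COc1ccc(C(=O)/C=C/c2cc(-c3cc(OC)c(OC)c(OC)c3)n[nH]2)cc1` gives -4%. Compound 4 `COc1cc(C(=O)/C=C/c2cc(-c3cc(OC)c(OC)c(OC)c3)n[nH]2)cc(OC)c1OC` differs from compound 1 by methoxy in place of hydrogen on an aromatic carbon. The bearing step is the removal of a methoxy from the same ring, a number 93 percentage points higher from compound 1 to compound 2 (beyond the scatter); the opposite move, adding a methoxy there, is therefore not expected to weaken the effect. The steps of a number 60 percentage points higher from compound 1 to compound 3 (beyond the scatter) and a number 33 percentage points lower from compound 2 to compound 3 (beyond the scatter) concern the other substituents on that ring and add little. Since compound 1 already shows near-complete cytotoxicity, compound 4 is expected to stay within scatter, a number 2 percentage points higher from compound 1 to compound 4 (within the scatter), giving an estimate of -95% (range -108% to -72%).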

Compound 4, a percentage reported as activity, at one concentration (the size of the read-out at that concentration, not a potency): -99%
Beside the measured number, compound 4's estimate is 4 percentage points above it; measured number inside the range.
By their numbers in this assay, from the lowest: compounds 4 and 1 (each within the scatter of the next); then compound 3; then compound 2.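

In this assay, methoxy in place of hydrogen on this aromatic carbon, ortho to a methoxy group, leaves the read-out unchanged: a number 2 percentage points lower from compound 1 to compound 4 (within the scatter). Going by these compounds alone, the ring therefore accepts this further methoxy without loss, which the earlier compounds, all with fewer methoxy groups on that ring, could not show. Nothing available here explains this tolerance.

On these data alone, whether an amine or a carboxylic acid on this carbon would also keep the effect remains open. As far as these compounds go, with one concentration, whether compound 1 and compound 4 would differ in effect at any other concentration also remains open.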